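The compounds below may be only part of what the source reports. "The series", "measured", "known", "first", "only" and "open" are said of these compounds alone.

The shared core carries a prenyloxy-substituted chlorophenyl amine, and the series varies the heteroaryl on that nitrogen. Compound 1 `CC(C)=CCOc1cc(Nc2nccs2)ccc1Cl` gives 26000 nM in a functional assay on MT2 cells (Homo sapiens) for cytotoxicity, read by MTT assay; a lower number here means that less compound is tolerated, a higher number that more compound is tolerated. Compound 2 `CC(C)=CCOc1cc(Nc2nccc(C)n2)ccc1Cl` is reported in this assay only as a limit of the assay, < 200 nM, and no number is known for it. Compound 3 `CC(C)=CCOc1cc(Nc2nccc(C(F)(F)F)n2)ccc1Cl` gives 2500 nM in this assay.

The two measured steps are both large. From compound 1 to compound 2 the move to 4-methylpyrimidin-2-yl in place of 1,3-thiazol-2-yl brings an at least 130-fold lower number from compound 1 to compound 2 (2.11 log units; beyond the scatter); from compound 2 to compound 3 the trifluoromethyl in place of methyl brings an at least 12-fold higher number from compound 2 to compound 3 (1.09 log units; beyond the scatter). Since compound 2 sits at the limit, the limit of < 200 nM in this assay, at which 1 of the 3 values shown sits, is the only anchor for its position, and it stands as the least tolerated of the three.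

Compound 4 `CC(C)=CCOc1cc(Nc2nc(C)cc(N)n2)ccc1Cl` differs from compound 2 by amino in place of hydrogen on an aromatic carbon. Among the measured compounds shown here, only the step from compound 2 to compound 3 touches the same six-membered aromatic ring with 2 nitrogen, and it moved the number upward by a large amount. A second substituent there is therefore expected to shift the number away from the limit, though more modestly: an at least 5.0-fold higher number from compound 2 to compound 4 (0.69 log units; beyond the scatter) is the estimated step. Compound 4 is expected to give about 1000 nM in this assay, within 200 nM to 5000 nM.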

Compound 4, half-maximal cytotoxic concentration: < 4 nM
Compound 4: a limit, no number; the forecaster's own chance of this, stated with the estimate: 30%; middle value at least 250-fold (2.39 log units) from the limit.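

No new step can be read between compound 2 and compound 4, as both stand in this assay only as limits of the assay and the two limits leave the step unreadable. The compounds shown leave open where compound 2 and compound 4 truly lie in this assay, and so how large the step with amino in place of hydrogen is.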